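The source may hold more compounds than are shown below. What is called first, only, known or untested is meant among the compounds shown, and "the series" means these compounds.

Working notes on the series. Compound 1 `Clc1cc(Cl)cc(CO[C@H]2CCCN(Cc3ccncc3)[C@H]2c2ccccc2)c1` carries pyridin-4-yl on a saturated chain carbon bound to an amine nitrogen in a ring. In an assay on isolated protein for activation of cGMP-dependent protein kinase 1 (Homo sapiens), read by ADP-Glo, with stated times of 120 min and 40 min (on this read-out higher numbers stand for an effect only at larger amounts of compound and lower numbers for an effect already at smaller amounts), compound 1 returns > 200000 nM, which is a limit of the assay and not a number (the limit of > 200000 nM in this assay, at which 1 of the 3 values shown sits). Compound 2 `O=C(O)c1ccc(CN2CCC[C@H](OCc3cc(Cl)cc(Cl)c3)[C@@H]2c2ccccc2)s1` gives 76000 nM in this assay, and compound 3 `Cn1cc(CN2CCC[C@H](OCc3cc(Cl)cc(Cl)c3)[C@@H]2c2ccccc2)cn1` gives 110000 nM. Compound 3 thus holds the higher of the two numbers, with compound 2 nearest, but a 1.4-fold higher number from compound 2 to compound 3 (0.16 log units; within the scatter) lies within the scatter, so no order between them is claimed. The step of an at least 2.6-fold lower number from compound 1 to compound 2 (0.42 log units; beyond the scatter) is beyond the scatter, starting from the limit, whereas an at least 1.8-fold lower number from compound 1 to compound 3 (0.25 log units; that floor lies within the scatter) has a floor within the scatter.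

Compound 4 `COc1cc(C(=O)O)ccc1CN1CCC[C@H](OCc2cc(Cl)cc(Cl)c2)[C@@H]1c1ccccc1` differs from compound 3 in one place: 4-carboxy-2-methoxyphenyl in place of 1-methyl-1H-pyrazol-4-yl on a saturated chain carbon bound to an amine nitrogen in a ring. Going by the values given here, the steps that bear on it are the exchanges of the ring on that carbon. Compound 2, carrying 5-carboxythiophen-2-yl at the same place, sits within the scatter of compound 3, and the pyrazole-to-thiophene exchange a 1.4-fold higher number from compound 2 to compound 3 (0.16 log units; within the scatter) shows no real movement. Accordingly no step beyond the scatter is expected here, leaning if anything toward a lower number; the expected step is a 1.7-fold lower number from compound 3 to compound 4 (0.23 log units; within the scatter). For compound 4 the estimate in this assay is 65000 nM, with a range from 22000 nM to 190000 nM.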

Compound 4, half-maximal effective concentration: 62000 nM
Compound 4: the middle estimate sits 1.0-fold (0.02 log units) above what was measured, and the stated range covers the measured number.
By their numbers in this assay, from the lowest: compounds 4, 2 and 3 (each within the scatter of the next). At a limit, above all of these: compound 1.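

The place on a saturated chain carbon bound to an amine nitrogen in a ring accommodates 4-carboxy-2-methoxyphenyl, with 11 heavy atoms against the 6 of 1-methyl-1H-pyrazol-4-yl, without a reading beyond the scatter: the series shows a 1.8-fold lower number from compound 3 to compound 4 (0.25 log units; within the scatter) and a 1.2-fold lower number from compound 2 to compound 4 (0.09 log units; within the scatter). Going by these compounds alone, a six-membered carbon ring bearing a carboxylic acid therefore reads with the five-membered rings of compound 2 and compound 3, and an at least 3.2-fold lower number from compound 1 to compound 4 (0.50 log units; beyond the scatter) gives a second step clear of the scatter, after the one to compound 2, although compound 3, without a carboxylic acid, stays within the scatter of both and so goes against any reading that ties the gain to the acid. Compound 1 stands at a limit, so that step is only a floor: the limit of > 200000 nM in this assay, at which 1 of the 4 values shown sits.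

The compounds shown do not separate the carboxylic acid from the methoxy group on the phenyl ring, and a phenyl ring carrying only one of them would do so. Going by these compounds, whether a primary amide, a tetrazole or a saturated chain ending in a carboxylic acid at this place would move the number beyond the scatter also stays open.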